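Adding an Amino Group to a Chloropurine Benzyl Compound

The source may report more compounds than this note shows. Statements on the series, on what has been measured and on what is new or still open speak of the compounds shown alone.

Compound 1 `ClCc1ccc(Cn2cnc3c(Cl)ncnc32)cc1` carries a chloromethyl-substituted benzyl group on a chloro-substituted shared core. In a functional assay on SNB-75 cells (Homo sapiens) for cytotoxicity, read by sulforhodamine B assay, with a stated time of 48 h (a higher number here means a weaker inhibitor of growth, a lower number a stronger inhibitor of growth), compound 1 gives "not determined" (no result reported), so no number exists for compound 1. A related compound, compound 2 `ClCc1cccc(Cn2cnc3c(Cl)nc(Cl)nc32)c1`, which also carries a chloromethyl-substituted benzyl group but has a second chloro group on its core, has been measured: in this assay compound 2 gives 3890 nM. Compound 3 `Nc1nc(Cl)c2ncn(Cc3ccc(CCl)cc3)c2n1` is compound 1 with a single change: amino in place of hydrogen on an aromatic carbon. Going by the values given here, no measured pair shows what this change does, so the step from compound 1 to compound 3 in this assay is expected to be small, within the usual scatter, with no clear direction. Compound 3 is estimated at 5000 nM, expected to fall between 1500 nM and 20000 nM, with compound 2 at 3890 nM serving as the only measured anchor.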

Compound 3, concentration for total growth inhibition: 91200 nM
For compound 3 the middle estimate is 18-fold (1.26 log units) below the measured one; the measured number lies above the stated range.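

Compound 1 has no single number in this assay, so the step to compound 3 cannot be read. What amino in place of hydrogen does to growth inhibition stays open, and nothing shown here explains the result for compound 3.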